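The source may hold more compounds than are shown below. What is called first, only, known or untested is meant among the compounds shown, and "the series" means these compounds.

Measured so far:
compound 1 `COc1cc(N2C(N)=C(C#N)C(c3c(O)ccc4ccccc34)C3=C2CC(C)(C)CC3=O)cc(OC)c1OC` — 15%
compound 2 `COc1cc(N2C(N)=C(C#N)C(c3cccs3)C3=C2CC(C)(C)CC3=O)cc(OC)c1OC` — 15%
compound 3 `COc1cc(N2C(N)=C(C#N)C(c3ccccc3Cl)C3=C2CC(C)(C)CC3=O)cc(OC)c1OC` — 20%

In a functional assay on Ehrlich cells (Mus musculus) for cytotoxicity, tested at 50 ug/mL (a lower number here means a weaker effect, a higher number a stronger effect of the compound at the concentration tested), compound 3 gives 20%, the top number of the three, but only by margins inside the scatter: a number 5 percentage points higher from compound 1 to compound 3 (within the scatter) and a number 5 percentage points higher from compound 2 to compound 3 (within the scatter). The remaining measured pair behaves the same way, no change at the digits printed from compound 1 to compound 2 (within the scatter).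

Compound 4 `COc1cc(N2C(N)=C(C#N)C(c3ccc(C)cc3)C3=C2CC(C)(C)CC3=O)cc(OC)c1OC` differs from compound 3 by 4-methylphenyl in place of 2-chlorophenyl on a saturated ring carbon. All three measured steps exchange the group on this same saturated ring carbon, and none of them moved the read-out beyond the scatter, so a fourth exchange at that carbon is expected to behave alike. The expected step is a number 3 percentage points lower from compound 3 to compound 4 (within the scatter), no change beyond the scatter. Compound 4 is estimated at 17%, with a range of 8% to 30%.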

Compound 4, a percentage reported as activity, at one concentration (the size of the read-out at that concentration, not a potency): 60%
Beside the measured number, compound 4's estimate is 43 percentage points below it, outside the stated range (above it).
By their numbers in this assay, from the lowest: compounds 1, 2 and 3 (each within the scatter of the next); then compound 4.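

In this assay the saturated ring carbon proves sensitive to its group after all: 4-methylphenyl gives a number 40 percentage points higher from compound 3 to compound 4 (beyond the scatter), a number 45 percentage points higher from compound 2 to compound 4 (beyond the scatter) and a number 45 percentage points higher from compound 1 to compound 4 (beyond the scatter), all beyond the scatter. The step from 2-chlorophenyl is large even though both groups count the same heavy atoms and carry no hydrogen-bond donors or acceptors, so those counts do not separate them. No measurement at hand accounts for the jump.

From the compounds shown here alone, whether the gain follows the methyl group or the loss of chlorine stays open. Phenyl, 2-methylphenyl and 4-chlorophenyl at this carbon would separate the two readings.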